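Chloro on the benzyl ring of a bombesin receptor agonist

The compounds below may be only part of what the source reports. "The series", "measured", "known", "first", "only" and "open" are said of these compounds alone.

Three compounds share one core, a biphenyl carboxylic acid linked through a two-carbon chain to an imidazole, and differ only in the group on the imidazole carbon. Compound 1 `CC(C)(C)c1cnc(CCc2ccc(-c3ccccc3C(=O)O)cc2)[nH]1` carries tert-butyl and in an in vitro functional assay on cells for agonist activity at Bombesin receptor subtype-3 (Mus musculus), read by luminescence and calcium flux (a lower number here means that less compound is needed, a higher number that more compound is needed for the effect), compound 1 gives 2750 nM. Compound 2 `N#Cc1ccccc1Cc1cnc(CCc2ccc(-c3ccccc3C(=O)O)cc2)[nH]1` carries 2-cyanobenzyl, and in this assay compound 2 gives 642 nM, so that a 4.3-fold lower number from compound 1 to compound 2 (0.63 log units; beyond the scatter). Compound 3 `O=C(O)c1ccccc1-c1ccc(CCc2ncc(Cc3ccccc3)[nH]2)cc1` carries benzyl, and in this assay compound 3 gives 11 nM; this is the lowest of the three numbers, with a 250-fold lower number from compound 1 to compound 3 (2.40 log units; beyond the scatter) and a 58-fold lower number from compound 2 to compound 3 (1.77 log units; beyond the scatter).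

Compound 4 `O=C(O)c1ccccc1-c1ccc(CCc2ncc(Cc3cccc(Cl)c3)[nH]2)cc1` is compound 3 with chloro in place of hydrogen on an aromatic carbon. Going by the values given here, no measured step places a chloro on this ring; the only comparison that touches a substituent on the benzyl ring is the step from compound 2 to compound 3, where removing a cyano gave a 58-fold lower number from compound 2 to compound 3 (1.77 log units; beyond the scatter). A substituent on that ring therefore was costly once, and chloro is expected to cost less but still to move the number upward, a 2.7-fold higher number from compound 3 to compound 4 (0.44 log units; beyond the scatter). Compound 4 is thus estimated at 30 nM in this assay, within a range of 8 nM to 120 nM.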

Compound 4, half-maximal effective concentration: 31 nM
The estimate for compound 4 lay 1.0-fold (0.01 log units) below the measured number, and the stated range covers the measured number.
By their numbers in this assay, from the lowest: compound 3; then compound 4; then compound 2; then compound 1.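

In this assay, the benzyl ring of compound 3 proves to tolerate a chloro on an aromatic carbon, meta to a large group, at a modest cost, with a 2.8-fold higher number from compound 3 to compound 4 (0.45 log units; beyond the scatter). The 3-chlorobenzyl group of compound 4 still retains a large advantage over the groups of the two weaker compounds, with a 21-fold lower number from compound 2 to compound 4 (1.32 log units; beyond the scatter) and an 89-fold lower number from compound 1 to compound 4 (1.95 log units; beyond the scatter), so a substituent on this ring does not by itself bring a loss as large as that seen with 2-cyanobenzyl. Nothing available explains the size of these steps.

From the compounds shown here alone, whether the gap between 3-chlorobenzyl and 2-cyanobenzyl follows the group or its place on the ring remains open, as the chloro and the nitrile occupy different places here. Going by these compounds, how 2-chlorobenzyl, 3-cyanobenzyl or 3-methoxybenzyl would compare also remains open.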